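This account rests on a few compounds, and the source may have more. Where it says the series, first, only, none or still open, it means among the compounds named here.

Measured compounds: compound 1 `COc1cc(-c2cc(/C=C/C(=O)c3ccc(N)cc3)[nH]n2)cc(OC)c1OC` gives 4820 nM in a functional assay on HT-29 cells (Homo sapiens) for inhibition, read by sulforhodamine B assay, with a stated time of 48 h; a lower number here means a stronger inhibitor of growth, a higher number a weaker inhibitor of growth; compound 2 `COc1ccc(C(=O)/C=C/c2cc(-c3cc(OC)c(OC)c(OC)c3)n[nH]2)cc1OC` gives 3050 nM; compound 3 `COc1ccc(C(=O)/C=C/c2cc(-c3cc(OC)c(OC)c(OC)c3)n[nH]2)cc1` gives 4190 nM.

Compound 3 sits among the other two with no separation of note: the step of a 1.2-fold lower number from compound 1 to compound 3 (0.06 log units; within the scatter) and the step of a 1.4-fold higher number from compound 2 to compound 3 (0.14 log units; within the scatter) both fall inside the scatter. Compound 4 `COc1cc(-c2cc(/C=C/C(=O)c3ccc(F)c(F)c3)[nH]n2)cc(OC)c1OC` differs from compound 3 in that (3,4-difluorophenyl in place of 4-methoxyphenyl on a carbonyl carbon). The three known steps, a 1.6-fold lower number from compound 1 to compound 2 (0.20 log units; within the scatter), a 1.2-fold lower number from compound 1 to compound 3 (0.06 log units; within the scatter) and a 1.4-fold higher number from compound 2 to compound 3 (0.14 log units; within the scatter), all alter the same aryl ring on the carbonyl carbon and all stay within the scatter, so no step beyond the scatter is expected in this assay for compound 4 either. Compound 4 is therefore estimated at 4000 nM, with a range of 1500 nM to 11000 nM, a step of a 1.0-fold lower number from compound 3 to compound 4 (0.02 log units; within the scatter).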

Compound 4, concentration for total growth inhibition: 6460 nM
For compound 4 the middle estimate is 1.6-fold (0.21 log units) below the measured one; low and high end bracket the measured number.
By their numbers in this assay, from the lowest: compounds 2, 3, 1 and 4 (each within the scatter of the next, the first and the last beyond it).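

In this assay, going by these compounds alone, putting 3,4-difluorophenyl on the carbonyl carbon gives the only step in this set that lies beyond the scatter, and a modest one: a 2.1-fold higher number from compound 2 to compound 4 (0.33 log units; beyond the scatter), where it replaces 3,4-dimethoxyphenyl. The steps of a 1.5-fold higher number from compound 3 to compound 4 (0.19 log units; within the scatter) and a 1.3-fold higher number from compound 1 to compound 4 (0.13 log units; within the scatter) stay within the scatter, so the separation holds against only one of the three earlier groups. Nothing available explains this step. As far as these compounds go, whether a 4-hydroxyphenyl or 4-carboxyphenyl group on the same carbonyl carbon would shift the number further remains open.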